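Methyl on the Ring: Compound 2 to Compound 4

This account rests on a few compounds, and the source may have more. Where it says the series, first, only, none or still open, it means among the compounds named here.

In a functional assay on the whole organism (stomach) with Rattus norvegicus as the target (a higher number here means that more compound is needed for the effect, a lower number that less compound is needed), compound 2 `C/N=C(/NC#N)NCCCn1nc(-c2ccccc2)ccc1=O` gives only a limit of the assay, > 100 mg/kg. Compound 1 `C/N=C(\S)NCCCn1nc(-c2ccccc2)ccc1=O` likewise gives only a limit, > 100 mg/kg. Among the compounds with values here, compound 3 `CN(C)/C(=N/CCCn1nc(-c2ccccc2)ccc1=O)NC#N` gives 53 mg/kg, so the step of an at least 1.8-fold lower number from compound 2 to compound 3 (0.27 log units; that floor lies within the scatter) is the one readable step from compound 2, while the step that the two limits leave unreadable from compound 1 to compound 2 cannot be sized; the limit of > 100 mg/kg in this assay, at which 2 of the 3 values shown sit, is where compound 1 and compound 2 sit. Compound 4 `C/N=C(/NC#N)NCCCn1nc(-c2ccccc2)cc(C)c1=O` differs from compound 2 by methyl in place of hydrogen on an aromatic carbon. Within the data shown here, no measured step touches this ring; the two readable steps change the chain end instead. The expected step is therefore a step that the limit leaves unreadable from compound 2 to compound 4, none beyond the scatter, with a limit again likely. Compound 4 is estimated at 150 mg/kg, between 50 mg/kg and 450 mg/kg.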

Compound 4, dose for half-maximal effect: > 100 mg/kg
Compound 4 was reported as a limit; the forecaster's own chance of this, stated with the estimate: 70%; the middle value lies beyond the limit too.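

Compound 2 and compound 4 both give only a limit in this assay, so no step between them can be read: the limit of > 100 mg/kg in this assay, at which 3 of the 4 values shown sit.

The compounds shown leave open whether methyl in place of hydrogen on this aromatic carbon changes the dose needed at all.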